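Arylhydrazone acids against kynurenine transaminase: working notes

The compounds below may be only part of what the source reports. "The series", "measured", "known", "first", "only" and "open" are said of these compounds alone.

Measured so far:
- Compound 1, `O=C(O)CCc1c(C(=O)O)[nH]c2ccc([N+](=O)[O-])cc12`: 666000 nM
- Compound 2, `CCOC(=O)/C(CCCC(=O)O)=N\Nc1cccc(Cl)c1`: 20000 nM

Both numbers come from an assay on isolated protein for inhibition of kynurenine--oxoglutarate transaminase 1 (Homo sapiens), read by HPLC, with a stated time of 20 min; on this read-out lower numbers stand for stronger inhibition and higher numbers for weaker inhibition. Compound 1, an indole bearing a nitro group and two acid groups, gives 666000 nM in this assay. Compound 2, a hydrazone ester carrying a chain acid, gives 20000 nM in this assay. Of the two numbers compound 2 holds the lower one; the gap up to compound 1 lies well beyond the usual scatter, so compound 2 is the stronger inhibitor of the pair on this read-out. The two compounds share no common core, so no single structural step can be read between them.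

Compound 3, `CCOC(=O)/C(CCCC(=O)O)=N\Nc1ccc(I)cc1`, has not yet been measured in this assay. It keeps the ester, the hydrazone and the chain acid of compound 2 and differs in one place: 4-iodophenyl in place of 3-chlorophenyl on an amine nitrogen. Among the compounds with values here, no measured pair shows what such a swap of one halogenated phenyl for another does here, so its step size cannot be taken from the data. The step from compound 2 to compound 3 is expected to stay within the scatter, no change at the digits printed from compound 2 to compound 3 (within the scatter), with no clear direction. Compound 3 is therefore expected to give about 20000 nM in this assay, within a range from 5000 nM to 80000 nM.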

Compound 3, half-maximal inhibitory concentration: 34000 nM
Beside the measured number, compound 3's estimate is 1.7-fold (0.23 log units) below it, and the stated range covers the measured number.
By their numbers in this assay, from the lowest: compounds 2 and 3 (each within the scatter of the next); then compound 1.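

In this assay, within the data shown here, 4-iodophenyl in place of 3-chlorophenyl on an amine nitrogen gives a 1.7-fold higher number from compound 2 to compound 3 (0.23 log units; within the scatter), the first step that can be read from a matched pair. This place therefore accepts the exchange of one halogenated phenyl for the other with no change that can be separated from the scatter on this read-out, even though the halogen and the number in the group's name both differ. The data offer no measurement that bears on the reason for this outcome.

Among these compounds, the single step changes the halogen and its stated ring position together, so the contribution of each stays unresolved, and with only these two groups at this place it remains open whether the halogen matters at all. Also open, going by these compounds, are how a plain phenyl, a 4-methoxyphenyl or a benzyl group on the same nitrogen would read, and whether a carboxylic acid in place of the ester or a longer chain to the acid would shift the number beyond the scatter.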